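A Cyclobutyl Amide Follows a Urea at the Limit

The compounds below may be only part of what the source reports. "The series", "measured", "known", "first", "only" and "open" are said of these compounds alone.

Compound 1 `O=C(c1cccc(F)c1)N1CC(c2nc(-c3cccc(Cl)c3)no2)C1` gives 780 nM in an assay on HEK293 cells for negative allosteric modulation of metabotropic glutamate receptor 5 (Homo sapiens), read by FLIPR; on this read-out higher numbers stand for weaker inhibition and lower numbers for stronger inhibition. Compound 2 `O=C(c1ccc(F)cc1)N1CC(c2nc(-c3cccc(Cl)c3)no2)C1` gives 4000 nM in this assay, a change of a 5.1-fold higher number from compound 1 to compound 2 (0.71 log units; beyond the scatter). Compound 3 `CC1CCN(C(=O)N2CC(c3nc(-c4cccc(Cl)c4)no3)C2)C1` stands apart: in this assay compound 3 gives > 10000 nM, which is a limit of the measurement and not a number. It sits at the limit of > 10000 nM in this assay, at which 1 of the 3 values shown sits, the weak edge of the set. The measured steps reaching it are an at least 12-fold higher number from compound 1 to compound 3 (1.10 log units; beyond the scatter) and an at least 2.5-fold higher number from compound 2 to compound 3 (0.39 log units; beyond the scatter). Compound 4 `O=C(C1CCC1)N1CC(c2nc(-c3cccc(Cl)c3)no2)C1` carries the change (cyclobutyl in place of 3-methylpyrrolidin-1-yl on a carbonyl carbon). Both steps bear on it, since each swap of 3-fluorophenyl or 4-fluorophenyl for 3-methylpyrrolidin-1-yl on the carbonyl carbon lost potency, and compound 4 restores no aryl there. One therefore expects little movement, an at least 1.1-fold lower number from compound 3 to compound 4 (0.04 log units; that floor lies within the scatter), with compound 4 estimated near 9000 nM, between 2500 nM and 30000 nM.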

Compound 4, half-maximal inhibitory concentration: 1500 nM
For compound 4 the middle estimate is 6.0-fold (0.78 log units) above the measured one, and the stated range ends above it.
By their numbers in this assay, from the lowest: compounds 1 and 4 (each within the scatter of the next); then compound 2. At a limit, above all of these: compound 3.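

The carbonyl carbon does not need an aryl group to keep potency: cyclobutyl gives an at least 6.6-fold lower number from compound 3 to compound 4 (0.82 log units; beyond the scatter) and so shows that the loss with 3-methylpyrrolidin-1-yl does not extend to every non-aryl group. Cyclobutyl is not separated from 3-fluorophenyl by a 1.9-fold higher number from compound 1 to compound 4 (0.28 log units; within the scatter) but does outperform 4-fluorophenyl with a 2.7-fold lower number from compound 2 to compound 4 (0.43 log units; beyond the scatter) on this read-out. The value of compound 3 is a limit of the measurement, not a number: the limit of > 10000 nM in this assay, at which 1 of the 4 values shown sits.

Going by these compounds, it remains open whether ring size governs this potency. Cyclopropyl, cyclopentyl or an unsubstituted pyrrolidin-1-yl on the same carbonyl carbon would test that.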